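A few compounds are considered here, and "the series" means these few. Any claim that something is new, unique, unknown or untested is made for them only; others in the source may bear on it.

In an assay (strain Wistar) for inhibition of Amine oxidase [flavin-containing] A (Rattus norvegicus) (a lower number here means a stronger inhibitor, a higher number a weaker inhibitor), compound 1 `NC(=O)Cc1cc(=O)oc2cc(OCc3cccc(Cl)c3)ccc12` gives 26000 nM. Compound 2 `NC(=O)Cc1cc(=O)oc2cc(OCc3cccnc3)ccc12` gives 21000 nM. Compound 3 `NC(=O)Cc1cc(=O)oc2cc(OCc3ccncc3)ccc12` gives 26500 nM.

Compound 1 stands second highest of these three numbers, nearest to compound 3 and furthest from compound 2, both within the scatter. The three measured steps, a 1.2-fold lower number from compound 1 to compound 2 (0.09 log units; within the scatter), a 1.0-fold higher number from compound 1 to compound 3 (0.01 log units; within the scatter) and a 1.3-fold higher number from compound 2 to compound 3 (0.10 log units; within the scatter), all exchange the aryl group on the saturated chain carbon bound to an oxygen on an aromatic ring, and none reaches beyond the scatter.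

Compound 4 `NCc1cc(=O)oc2cc(OCc3cccc(Cl)c3)ccc12` differs from compound 1 at another place: amino in place of carbamoyl on a saturated chain carbon bound to an aromatic carbon. Among the measured compounds shown here, no measured step touches this site, so the measured steps give no direction for it. Compound 4 is therefore expected near 15000 nM, within 3000 nM to 80000 nM. The expected step is a 1.7-fold lower number from compound 1 to compound 4 (0.24 log units; within the scatter).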

Compound 4, half-maximal inhibitory concentration: 2000 nM
Compound 4: middle estimate off by 7.5-fold (0.88 log units), on the high side; measured number below the stated range.
By their numbers in this assay, from the lowest: compound 4; then compounds 2, 1 and 3 (each within the scatter of the next).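

The site on the saturated chain carbon bound to an aromatic carbon proves responsive in this assay: amino in place of carbamoyl gives a 13-fold lower number from compound 1 to compound 4 (1.11 log units; beyond the scatter), whereas the earlier exchanges of the aryl group all stayed within the scatter. This change, carbamoylmethyl to aminomethyl, is the first shown here to move the number beyond the scatter. Nothing available gives a reason for the step. Going by these compounds, whether the same change holds with the pyridin-3-yl of compound 2 or the pyridin-4-yl of compound 3 stays open. So does how a carboxylic acid or a longer chain carrying the amine would behave at this site.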